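The compounds below may be only part of what the source reports. "The series", "measured", "known", "first", "only" and "open" are said of these compounds alone.

Measured in a toxicity assay on Huh-7.5 cells (Homo sapiens) for inhibition, read by MTT assay, with a stated time of 96 h; on this read-out lower numbers stand for higher toxicity in this test and higher numbers for lower toxicity in this test:
- Compound 1 `CN1CCN(Cc2ccc(NC(=O)c3ccc(OCCCCl)c(S(N)(=O)=O)c3)cc2C(F)(F)F)CC1`: 5470 nM
- Compound 2 `CCC(=O)Nc1cc(C(=O)Nc2ccc(N(C)C)cc2)ccc1OC`: 171000 nM
- Compound 3 `CCOc1ccc(C(=O)Nc2ccc(OC)cc2)cc1NC(=O)CC`: 73200 nM

Compound 1 has the lowest number of the three, and both other values lie well beyond the scatter from it. Compound 4 `CN1CCN(Cc2ccc(NC(=O)c3ccc(OCCCCl)c(C(F)(F)F)c3)cc2C(F)(F)F)CC1` keeps the core of compound 1 and changes one group: trifluoromethyl in place of sulfamoyl on an aromatic carbon. For the measured compounds named here, no measured pair of compounds shows what this swap does, so the data offer no direct guide. The expectation is therefore no step beyond the scatter in this assay, in either direction. The estimated step is a 1.1-fold lower number from compound 1 to compound 4 (0.04 log units; within the scatter). For compound 4 the expected value is 5000 nM, with an estimated range from 1800 nM to 14000 nM.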

Compound 4, half-maximal cytotoxic concentration: 13400 nM
Compound 4: the middle estimate sits 2.7-fold (0.43 log units) below what was measured; low and high end bracket the measured number.
By their numbers in this assay, from the lowest: compound 1; then compound 4; then compound 3; then compound 2.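

In this assay, trifluoromethyl in place of sulfamoyl on this aromatic carbon, ortho to a 3-chloropropoxy group, gives a 2.4-fold higher number from compound 1 to compound 4 (0.39 log units; beyond the scatter). The group at this position therefore affects the read-out, though the step is modest, and the higher number stands for lower toxicity in this test. Nothing available explains the step. With only this one swap shown, it remains open how a nitrile, a carboxylic acid or an amine on the same carbon would read, and whether the sulfamoyl group's hydrogen-bond donor or acceptors matter.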